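Working notes: compound 3 in the antiproliferative series

The compounds below may be only part of what the source reports. "The series", "measured", "known", "first", "only" and "open" are said of these compounds alone.

Measured so far:
compound 1, `COc1cc(-c2cc(C(=O)/C=C/c3ccccc3)nc3cc(-c4ccccc4)nn23)cc(OC)c1OC`, 19200 nM
compound 2, `COc1cc(-c2cc(/C=C/C(=O)c3ccc(C)cc3)nc3cc(-c4ccccc4)nn23)cc(OC)c1OC`, 23900 nM

Both numbers come from a functional assay on MDA-MB-231 cells (Homo sapiens) for antiproliferative activity, read by MTT assay, with a stated time of 24 h; on this read-out higher numbers stand for weaker inhibition and lower numbers for stronger inhibition. In this assay compound 2 gives the highest of the two numbers, with compound 1 as its nearest neighbour; the step of a 1.2-fold higher number from compound 1 to compound 2 (0.10 log units; within the scatter) lies within the scatter, so the two compounds cannot be put in order on this read-out.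

Compound 3, `COc1ccc(/C=C/C(=O)c2cc(-c3cc(OC)c(OC)c(OC)c3)n3nc(-c4ccccc4)cc3n2)cc1`, has not yet been measured. It differs from compound 2 in one place: (2-(4-methoxyphenyl)ethenyl)carbonyl in place of 2-((4-methylphenyl)carbonyl)ethenyl on an aromatic carbon. Among the compounds with values here, the only measured step that bears on this change, a 1.2-fold higher number from compound 1 to compound 2 (0.10 log units; within the scatter), also exchanged one such side chain for the other on the same aromatic carbon and moved the number by no more than the scatter. Compound 3 returns to the side-chain arrangement of compound 1 and carries a methoxy instead of a methyl; nothing measured here speaks to that methoxy on its own. The expected step in this assay is therefore a 1.2-fold lower number from compound 2 to compound 3 (0.08 log units; within the scatter), none beyond the scatter. For compound 3 the estimate in this assay is 20000 nM, with a range from 8000 nM to 50000 nM.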

Compound 3, half-maximal inhibitory concentration: 16500 nM
The estimate for compound 3 lay 1.2-fold (0.08 log units) above the measured number; the measured number falls inside the stated range.
By their numbers in this assay, from the lowest: compounds 3, 1 and 2 (each within the scatter of the next).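

In this assay, (2-(4-methoxyphenyl)ethenyl)carbonyl in place of 2-((4-methylphenyl)carbonyl)ethenyl on the aromatic carbon next to the ring nitrogen gives a 1.4-fold lower number from compound 2 to compound 3 (0.16 log units; within the scatter), so compound 1, compound 2 and compound 3 cannot be put in order, and this position has now taken three side chains with no separation on this read-out. Within the data shown here, the series also gains its only reading of a substituent on the phenyl ring of the (2-phenylethenyl)carbonyl side chain: methoxy in place of hydrogen gives a 1.2-fold lower number from compound 1 to compound 3 (0.07 log units; within the scatter), so in this pair the added methoxy produces no change that can be read. No supporting data are available to account for how closely these numbers lie.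

Still open, going by these compounds, is whether a group of another kind on that phenyl ring, such as an amine or a carboxylic acid, would separate from these three compounds in this assay. Also open, on these data alone, is whether a side chain at this position that lacks the ethenyl link, such as a simple amide or a longer saturated chain, would give a step beyond the scatter.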